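Naphthalen-2-yl replaces methoxycarbonylphenyl on the amine-linked benzyl

The compounds below may be only part of what the source reports. "The series", "measured", "known", "first", "only" and "open" are said of these compounds alone.

The series shares the core of compound 1 `COC(=O)c1cccc(CN(CCCC(=O)O)C[C@H]2O[C@@H](n3cnc4c(N)ncnc43)[C@H](O)[C@@H]2O)c1`, an amine-linked nucleoside with a benzyl arm. In an assay on cells for inhibition of Nicotinamide N-methyltransferase (Homo sapiens), with stated times of 10 min and 30 min (a higher number here means a weaker inhibitor, a lower number a stronger inhibitor), compound 1 reaches only a limit, > 250000 nM. Compound 2 `COC(=O)c1cccc(CN(CCCCC(=O)O)C[C@H]2O[C@@H](n3cnc4c(N)ncnc43)[C@H](O)[C@@H]2O)c1` carries carboxymethyl in place of carboxy on the saturated chain carbon three bonds along the chain from the amine nitrogen; in this assay compound 2 likewise gives a limit, > 250000 nM. Compound 3 `COC(=O)c1cccc(CN(C[C@H]2O[C@@H](n3cnc4c(N)ncnc43)[C@H](O)[C@@H]2O)C(C)C)c1` has isopropyl on the amine nitrogen; in this assay compound 3 also gives a limit, > 250000 nM. The steps a step that the two limits leave unreadable from compound 1 to compound 2, a step that the two limits leave unreadable from compound 1 to compound 3 and a step that the two limits leave unreadable from compound 2 to compound 3 are therefore unreadable, as all three values sit at the limit of > 250000 nM in this assay, at which 3 of the 3 values shown sit.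

Compound 4 `Nc1ncnc2c1ncn2[C@@H]1O[C@H](CN(CCCC(=O)O)Cc2ccc3ccccc3c2)[C@@H](O)[C@H]1O` differs from compound 1 in the change (naphthalen-2-yl in place of 3-(methoxycarbonyl)phenyl on a saturated chain carbon bound to an amine nitrogen), while the 3-carboxypropyl chain stays. Among the compounds with values here, no measured step touches this position, and the measured steps show no readable size, so the expectation rests on compound 1 alone. Compound 4 is estimated at 100000 nM (range 5000 nM to 250000 nM), which means an expected step of an at least 2.5-fold lower number from compound 1 to compound 4 (0.39 log units; beyond the scatter), with a real chance that only a limit is reported again.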

Compound 4, half-maximal inhibitory concentration: > 250000 nM
Compound 4: a limit, no number (the forecaster's own chance of this, stated with the estimate: 55%); middle value at least 2.5-fold (0.39 log units) from the limit.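

In this assay compound 4 gives only a limit, > 250000 nM, so the step from compound 1 to it cannot be read, and all compounds shown remain at that limit: the limit of > 250000 nM in this assay, at which 4 of the 4 values shown sit.

The compounds shown leave open which change to the shared core, if any, would give a readable number in this assay.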